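The source may report more compounds than this note shows. Statements on the series, on what has been measured and on what is new or still open speak of the compounds shown alone.

Compound 1, `CN1CCN(c2ccc(Nc3nc(-c4cccc(NC(=O)c5ccc(F)c(Cl)c5)c4)sc3C(=O)O)cc2)CC1`, gives 98.6% in a functional assay on Ramos cells (Homo sapiens) for antiproliferative activity, read by CCK-8 assay, with a stated time of 72 h, tested at 40 uM; a lower number here means less inhibition, a higher number more inhibition at the concentration tested (going by the name of the read-out).
Compound 2, `CN1CCN(c2ccc(Nc3nc(-c4cccc(NC(=O)c5ccccc5)c4)sc3C(N)=O)cc2)CC1`, gives 98.1% in this assay.
Compound 3, `CN1CCN(c2ccc(Nc3nc(-c4cccc(NC(=O)c5ccc(Cl)cc5)c4)sc3C(N)=O)cc2)CC1`, gives 99% in this assay.

Compound 3 has the highest of these three numbers, yet its gap to compound 1 and its gap to compound 2 both lie within the usual scatter, so the three compounds cannot be told apart on these data. Within the data shown here, the one step measured so far, chloro in place of hydrogen on an aromatic carbon, gives a number 0.9 percentage points higher from compound 2 to compound 3 (within the scatter).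

Compound 4, `CN1CCN(c2ccc(Nc3nc(-c4cccc(NC(=O)c5ccc(F)c(Cl)c5)c4)sc3C(N)=O)cc2)CC1`, has not been measured. It differs from compound 3 in one place: 3-chloro-4-fluorophenyl in place of 4-chlorophenyl on a carbonyl carbon. The group that enters is already present in compound 1, which differs from compound 4 in a second place as well, so no single step can be read from that pair; compound 1 simply shows that a compound carrying this group also reaches a high number, at 98.6%.

Among the measured compounds shown here, with all three measured numbers level with one another and the only measured step within the scatter, the expected change from compound 3 to compound 4 in this assay is none beyond the scatter, and a number 0.5 percentage points lower from compound 3 to compound 4 (within the scatter) is the step this estimate means. Compound 4 is therefore expected to give about 98.5%, with a likely range from 95% to 100%.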

Compound 4, a percentage reported as inhibition, at one concentration (the size of the read-out at that concentration, not a potency): 97.5%
Compound 4: middle estimate off by 1 percentage points, on the high side; the range from low to high includes it.
By their numbers in this assay, from the lowest: compounds 4, 2, 1 and 3 (each within the scatter of the next).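

In this assay, the group on the carbonyl carbon whose other neighbour is the amide-type nitrogen can be 3-chloro-4-fluorophenyl, 4-chlorophenyl or phenyl with no difference that can be told: the steps read a number 1.5 percentage points lower from compound 3 to compound 4 (within the scatter) and a number 0.6 percentage points lower from compound 2 to compound 4 (within the scatter). Among these compounds, the pair of compound 1 and compound 4 also gives the first reading of a second place, amino in place of hydroxy on a carbonyl carbon, and the carboxylic acid and the amide cannot be told apart here either, with a number 1.1 percentage points lower from compound 1 to compound 4 (within the scatter). Nothing at hand explains why these numbers sit level.

The compounds shown carry only a phenyl ring, plain or bearing halogen, on the amide carbonyl, so it remains open whether a pyridine ring, a methoxy group or a simple alkyl chain at that place would hold the number as high, and whether a methyl ester or a nitrile could replace the carboxylic acid or the amide. A single tested concentration is also not a potency, so any differences among these compounds at lower concentrations remain unknown.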